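Chloro for Fluoro on the Pendant Phenyl Ring

The source may report more compounds than this note shows. Statements on the series, on what has been measured and on what is new or still open speak of the compounds shown alone.

Measured compounds:
compound 1 `CCn1cc(-c2cccc(F)c2)c(=O)c2cc(F)c(N3CCNCC3)cc21`, 22000 nM
compound 2 `CCn1cc(-c2cccc(Cl)c2)c(=O)c2cc(F)c(N3CCNCC3)cc21`, 16100 nM
compound 3 `O=c1c(-c2ccc(F)cc2)cn(C2CC2)c2cc(N3CCNCC3)c(F)cc12`, 14900 nM

In a functional assay on HeLa cells (Homo sapiens) for antiproliferative activity, read by MTT assay, with a stated time of 48 h (on this read-out higher numbers stand for weaker inhibition and lower numbers for stronger inhibition), compound 1 gives 22000 nM and compound 2 gives 16100 nM. The change between them is chloro in place of fluoro on an aromatic carbon, and it made the step of a 1.4-fold lower number from compound 1 to compound 2 (0.14 log units; within the scatter). Compound 3, built on a different core, gives 14900 nM in this assay; the difference between the two cores is not broken down here. Compound 4 `O=c1c(-c2ccc(Cl)cc2)cn(C2CC2)c2cc(N3CCNCC3)c(F)cc12` carries the same kind of change on the core of compound 3, namely (chloro in place of fluoro on an aromatic carbon); here the place is para to a large group, whereas in compound 2 it is meta to a large group. The step from compound 3 to compound 4 is expected to be a 1.3-fold lower number from compound 3 to compound 4 (0.11 log units; within the scatter), resting on the step of a 1.4-fold lower number from compound 1 to compound 2 (0.14 log units; within the scatter) seen with the other core. Compound 4 is therefore estimated at 11500 nM in this assay, with a range from 5500 nM to 24000 nM.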

Compound 4, half-maximal inhibitory concentration: 9300 nM
Estimate against measurement, compound 4: 1.2-fold (0.09 log units) above; the measured number falls inside the stated range.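

In this assay, chloro in place of fluoro on the core of compound 3 gives a 1.6-fold lower number from compound 3 to compound 4 (0.20 log units; within the scatter). Set beside the step seen on the core of compound 1, the two agree: the same change on two cores in this assay, a 1.4-fold lower number (0.14 log units; within the scatter) from compound 1 to compound 2 and a 1.6-fold lower number (0.20 log units; within the scatter) from compound 3 to compound 4, 1.2-fold (0.07 log units) apart, within the scatter of two such steps This shows that the change reads alike on these two cores, but since each step lies within the scatter, it does not show that chloro truly improves on fluoro on either core, and the place of the change on the ring also differs between the two pairs.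

The compounds shown leave open whether a bromo, methoxy or nitrile group on the pendant phenyl ring would give a step beyond the scatter. They also leave open whether the agreement would hold on a third core.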